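The source may hold more compounds than are shown below. What is called first, only, known or untested is meant among the compounds shown, and "the series" means these compounds.

Compound 2 `C=CCn1c(=O)/c(=C\c2cccc(Br)c2)[nH]c(=O)/c1=C\c1ccccc1OC` gives 5400 nM in a functional assay on MCF7 cells (Homo sapiens) for cytotoxicity, read by CCK-8 assay, with a stated time of 72 h (a higher number here means a weaker inhibitor, a lower number a stronger inhibitor), the highest of the two numbers recorded there. Within the data shown here, its nearest neighbour is compound 1 `C=CCn1c(=O)/c(=C\c2cccc(Cl)c2Cl)[nH]c(=O)/c1=C\c1ccccc1OC`, which in this assay gives 2100 nM; the one step between them, a 2.6-fold higher number from compound 1 to compound 2 (0.41 log units; beyond the scatter), is a modest rise beyond the scatter.

Compound 3 `C=CCn1c(=O)/c(=C\c2cc(F)ccc2C)[nH]c(=O)/c1=C\c1ccccc1OC` differs from compound 2 by 5-fluoro-2-methylphenyl in place of 3-bromophenyl on a double-bonded chain carbon bound to an aromatic carbon. Among the measured compounds shown here, no measured step matches this change directly. For the measured compounds named here, the only step available, a 2.6-fold higher number from compound 1 to compound 2 (0.41 log units; beyond the scatter), shows that an aryl group carrying two halogens on the same carbon of the shared core gave a lower number than one carrying a single bromine, and compound 3 again carries two substituents on that ring, though neither is a chlorine. On this thin basis the author expects compound 3 to give a number somewhat lower than compound 2, a step of about a 1.5-fold lower number from compound 2 to compound 3 (0.19 log units; within the scatter), with a wide range of uncertainty. For compound 3 in this assay the estimate is 3500 nM, with a range from 1200 nM to 10000 nM.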

Compound 3, half-maximal inhibitory concentration: 3100 nM
The estimate for compound 3 lay 1.1-fold (0.05 log units) above the measured number, and the stated range covers the measured number.
By their numbers in this assay, from the lowest: compounds 1, 3 and 2 (each within the scatter of the next, the first and the last beyond it).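

In this assay, 5-fluoro-2-methylphenyl in place of 3-bromophenyl on a double-bonded chain carbon bound to an aromatic carbon gives a 1.7-fold lower number from compound 2 to compound 3 (0.24 log units; within the scatter), and the same group in place of 2,3-dichlorophenyl gives a 1.5-fold higher number from compound 1 to compound 3 (0.17 log units; within the scatter). Among these compounds, the earlier compounds offered only two halogen-bearing rings at this position, separated by a 2.6-fold higher number from compound 1 to compound 2 (0.41 log units; beyond the scatter); the new result shows that a ring carrying a methyl group and a fluorine, with neither chlorine nor bromine, cannot be told apart from either of them, so compound 3 sits within the scatter of both while those two remain distinct. No accompanying measurement bears on the reason for these numbers.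

The three compounds do not separate the share of the methyl group from that of the fluorine, since the two enter together and each aryl group here differs from the others in more than one substituent. They also leave open whether an aryl group bearing an amine or a carboxylic acid at this position would stay in the same range of numbers on these cells.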